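The source may hold more compounds than are shown below. What is called first, only, known or untested is meant among the compounds shown, and "the series" means these compounds.

Measured compounds:
- compound 1, `COc1ccc(-c2nnc(SCC(=O)c3ccccc3)n2-c2ccccc2)cc1OC`: 59%
- compound 2, `COc1cc(-c2nnc(SC/C(=N/O)c3ccccc3)n2-c2ccccc2)cc(OC)c1OC`: 64%
- compound 3, `C=CCn1c(SCC(=O)c2ccccc2)nnc1-c1cc(OC)c(OC)c(OC)c1`: 66%

In a functional assay on the whole organism (strain albino) for inhibition, with Rattus norvegicus as the target, read by paw edema, with a stated time of 3 h, at a dose of 0.28 mmol/kg by the oral route (a lower number here means less inhibition, a higher number more inhibition at the dose given (going by the name of the read-out)), compound 3 carries the highest number of the three, but compound 2 and compound 1 both fall within the scatter of it, so the three read as one level. Compound 4, `COc1cc(-c2nnc(SCC(=O)c3ccccc3)n2-c2ccccc2)cc(OC)c1OC`, differs from compound 3 by phenyl in place of allyl on an aromatic nitrogen. Going by the values given here, no measured pair isolates this change. Compound 1, which already carries phenyl on that nitrogen with a similar core, gives 59%, and compound 2 gives 64%; neither suggests a move beyond the scatter. The step of a number 4 percentage points lower from compound 3 to compound 4 (within the scatter) is therefore expected to be small, with no direction beyond the scatter. Compound 4 is estimated at 62%, within 50% to 72%.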

Compound 4, a percentage reported as inhibition, in the whole organism at one dose (the size of the read-out at that dose, not a potency): 68%
For compound 4 the middle estimate is 6 percentage points below the measured one; low and high end bracket the measured number.
By their numbers in this assay, from the lowest: compounds 1, 2, 3 and 4 (each within the scatter of the next).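

In this assay, phenyl in place of allyl on the aromatic nitrogen gives a number 2 percentage points higher from compound 3 to compound 4 (within the scatter) and so shows that this position carries either group without a step beyond the scatter. Benzoylmethyl in place of its oxime on the sulfur gives a number 4 percentage points higher from compound 2 to compound 4 (within the scatter) and methoxy in place of hydrogen on an aromatic carbon gives a number 9 percentage points higher from compound 1 to compound 4 (within the scatter), so neither change leaves the scatter either. No evidence on the cause of these readings is at hand.

Going by these compounds, whether a longer chain or an amine on that nitrogen would move the inhibition beyond the scatter remains open. The same holds for a carboxylic acid in place of the methoxy groups.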